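A few compounds are considered here, and "the series" means these few. Any claim that something is new, unique, unknown or untested is made for them only; others in the source may bear on it.

Working notes on a series built on the core of compound 1 `CCOC(=O)c1c(-c2ccccc2)nn(-c2ccccc2)c1COCc1c(-c2ccc(F)cc2)nc(N(C)S(C)(=O)=O)nc1C(C)C`, in which only the tail attached to the core is varied. In an assay for inhibition of Alpha amylase (Homo sapiens), with a stated time of 30 min (on this read-out higher numbers stand for weaker inhibition and lower numbers for stronger inhibition), compound 1 gives 15 ug/mL. Compound 2 `CCOC(=O)c1c(-c2ccccc2)nn(-c2ccccc2)c1Cn1cnc2cc(C)ccc21` gives 45 ug/mL in this assay, and compound 3 `CCOC(=O)c1c(-c2ccccc2)nn(-c2ccccc2)c1COc1cc(OC)c(C=O)c(OC)c1` gives 40 ug/mL in this assay. Compound 2 stands at the highest of the three numbers: its gap to compound 3 lies within the scatter, so no order is read between those two, while its gap to compound 1 lies beyond the scatter, which marks compound 1 as the stronger inhibitor of that pair.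

Compound 4 `CCOC(=O)c1c(-c2ccccc2)nn(-c2ccccc2)c1COCc1ccccc1` follows from compound 2 by benzyloxy in place of 5-methyl-1H-benzimidazol-1-yl on a saturated chain carbon bound to an aromatic carbon. Within the data shown here, no pair of measured compounds isolates this change, so no measured step guides the expectation. The nearest point of reference is compound 1, whose ether-linked tail gives 15 ug/mL, whereas compound 4 carries a plainer benzyloxy tail without the substituents seen in compound 1. The expectation is that the step of a 1.1-fold higher number from compound 2 to compound 4 (0.05 log units; within the scatter) in this assay comes out small, not beyond the scatter in either direction. For compound 4 the estimate in this assay is 50 ug/mL, with a range from 25 ug/mL to 100 ug/mL.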

Compound 4, half-maximal inhibitory concentration: 45 ug/mL
The estimate for compound 4 lay 1.1-fold (0.05 log units) above the measured number, within the range that was stated.
By their numbers in this assay, from the lowest: compound 1; then compounds 3, 2 and 4 (each within the scatter of the next).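

In this assay, no change at the digits printed from compound 2 to compound 4 (within the scatter), so on a saturated chain carbon bound to an aromatic carbon, 5-methyl-1H-benzimidazol-1-yl and benzyloxy read alike. Among the tails attached through oxygen, a 1.1-fold higher number from compound 3 to compound 4 (0.05 log units; within the scatter), so a group of 7 heavy atoms on an oxygen on a saturated carbon reads alike with the group of 12 heavy atoms that it replaces. Compounds 2, 3 and 4 therefore form a set within the scatter of one another, so neither the swap of benzimidazolyl for benzyloxy nor the added atoms on the aromatic ring of compound 3 separate these tails, while compound 1 at 15 ug/mL keeps the lowest number and compound 4 stands at 45 ug/mL.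

No supporting measurement bears on why these tails read alike. From the compounds shown here alone, it remains open which part of the larger tail of compound 1 goes with its lower number, and whether an amine or a carboxylic acid on the benzyl ring of compound 4, or a longer chain in place of its benzyloxy link, would move the number at all.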